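The source may report more compounds than this note shows. Statements on the series, on what has been measured and on what is new or still open speak of the compounds shown alone.

In a functional assay (muscle tissue) with Cavia porcellus as the target (a lower number here means that less compound is needed, a higher number that more compound is needed for the effect), compound 1 `COC(=O)C1=C(C)N=C(C)/C(=C(\O)OC)C1c1ccccc1Cl` gives 2.19 nM and compound 2 `COC(=O)C1=C(C)N=C(C)/C(=C(\O)OC)C1c1ccccc1OC` gives 57.5 nM, so compound 2 holds the higher of the two numbers. Compound 3 `COC(=O)C1=C(C)N=C(C)/C(=C(\O)OC)C1c1cccc(N)c1` differs from compound 2 on a saturated ring carbon, with 3-aminophenyl in place of 2-methoxyphenyl on a saturated ring carbon. For the measured compounds named here, the only measured step that bears on this change, a 26-fold higher number from compound 1 to compound 2 (1.42 log units; beyond the scatter), is large and also involves a group on this aromatic ring. Going by the values given here, no measured compound carries an amino group, so the direction remains uncertain. The expected change is a 2.6-fold higher number from compound 2 to compound 3 (0.42 log units; beyond the scatter), a modest rise. Compound 3 is estimated at 150 nM, with an expected range from 20 nM to 1000 nM.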

Compound 3, half-maximal effective concentration: 2000 nM
The estimate for compound 3 lay 13-fold (1.12 log units) below the measured number, outside the stated range (above it).
By their numbers in this assay, from the lowest: compound 1; then compound 2; then compound 3.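

In this assay, the aromatic group on the saturated ring carbon proves even more sensitive than the chloro-to-methoxy swap suggested: 3-aminophenyl in place of 2-methoxyphenyl gives a 35-fold higher number from compound 2 to compound 3 (1.54 log units; beyond the scatter), and in place of 2-chlorophenyl it gives a 910-fold higher number from compound 1 to compound 3 (2.96 log units; beyond the scatter). Compound 3 therefore has the highest number of the three. No available evidence accounts for this rise.

This change alters both the group and its place on the phenyl ring, and the compounds shown cannot separate these two effects. As far as these compounds go, how a nitro group or an unsubstituted phenyl ring would compare also remains open.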